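The compounds below may be only part of what the source reports. "The series", "measured", "known", "first", "only" and "open" are said of these compounds alone.

Measured so far in an assay on isolated protein for inhibition of DNA topoisomerase 1 (Homo sapiens), with a stated time of 15 min; on this read-out lower numbers stand for stronger inhibition and higher numbers for weaker inhibition:
- compound 1, `CNC(=O)c1cn(Cc2ccc(-c3ccccc3)cc2)c2c(OC)c(N3CC[C@@H](CN)C3)c(F)cc2c1=O`: 82100 nM
- compound 2, `COc1c(N2CC[C@@H](CN)C2)c(F)cc2c(=O)c(C(=O)O)cn(Cc3cc(-c4ccccc4)no3)c12`: 178000 nM
- compound 3, `O=C(O)c1cn(Cc2ccc(-n3cccn3)cc2)c2cc(NC[C@@H]3CCNC3)c(F)cc2c1=O`: 200000 nM

All three numbers sit in a weak range. Compound 1 holds the lowest of the three; compound 2 stands higher and compound 3 higher still, both gaps lying beyond the usual scatter. Among the compounds with values here, the three compounds differ from one another in several places at once, so no single-change step among them can be read.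

The next compound, compound 4, `COc1c(N2CC[C@@H](CN)C2)c(F)cc2c(=O)c(C(=O)NO)cn(Cc3ccc(-c4ccccc4)cc3)c12`, keeps the core of compound 1 and changes one thing: hydroxy in place of methyl on an amide-type nitrogen. In the wider reading this is methylcarbamoyl to hydroxycarbamoyl. Nothing measured here speaks to this change directly, and the three values give no single-step comparison of the same kind, so the expectation rests on compound 1 alone and on the small size of the change.

A step of modest size is expected, in either direction, most likely staying close to compound 1, as the estimated step of a 1.2-fold lower number from compound 1 to compound 4 (0.07 log units; within the scatter) shows. Compound 4 is estimated at 70000 nM in this assay, with a range from 20000 nM to 250000 nM.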

Compound 4, half-maximal inhibitory concentration: 35900 nM
Beside the measured number, compound 4's estimate is 1.9-fold (0.29 log units) above it; measured number inside the range.
By their numbers in this assay, from the lowest: compound 4; then compound 1; then compounds 2 and 3 (each within the scatter of the next).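

Within the data shown here, on the amide-type nitrogen of the shared core, hydroxy in place of methyl gives the first single-change step in this assay (a 2.3-fold lower number from compound 1 to compound 4 (0.36 log units; beyond the scatter)), a modest step that lies beyond the usual scatter. Among these compounds, this position therefore responds to the exchange of one heavy atom, with methyl bringing no hydrogen-bond donor or acceptor and hydroxy bringing one of each, although the number of compound 4 remains in the weak range seen for the earlier compounds. Nothing measured accounts for this step, and the contributions of the oxygen, the donor and the acceptor cannot be separated.

On these data alone, it remains open how other groups on this nitrogen would read, such as an amino group, a methoxy group or a longer chain such as ethyl, and how the unsubstituted amide would compare with methylcarbamoyl and hydroxycarbamoyl. As far as these compounds go, it also remains open whether methylcarbamoyl to hydroxycarbamoyl gives a step of similar size on a compound that differs from compound 1 elsewhere in the structure.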